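Removal of the chloro from compound 1

The source may report more compounds than this note shows. Statements on the series, on what has been measured and on what is new or still open speak of the compounds shown alone.

Measured so far:
compound 1, `Cc1ccc2nc(/N=C3\C(=O)N(CN4CCCCC4)c4cccc(Cl)c43)sc2c1`: 30900 nM
compound 2, `CCN(CC)CN1C(=O)/C(=N\c2nc3ccc(C)cc3s2)c2c(Cl)cccc21`: 19200 nM

In a functional assay on MCF7 cells (Homo sapiens) for cytotoxicity, read by sulforhodamine B assay, with a stated time of 48 h (a lower number here means a stronger inhibitor of growth, a higher number a weaker inhibitor of growth), compound 1 gives 30900 nM, the highest of the two numbers recorded. For the measured compounds named here, its nearest neighbour is compound 2 with 19200 nM; the single measured step is a 1.6-fold lower number from compound 1 to compound 2 (0.21 log units; within the scatter), and it concerns only the saturated chain carbon bound to the amide-type nitrogen in the ring.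

Compound 3, `Cc1ccc2nc(/N=C3\C(=O)N(CN4CCCCC4)c4ccccc43)sc2c1`, has not yet been measured. It differs from compound 1 in one place: hydrogen in place of chloro on an aromatic carbon. Going by the values given here, no measured step touches the aromatic carbon that carries the chloro, so nothing here speaks to the size or direction of this change. Among the compounds with values here, the one step that exists, a 1.6-fold lower number from compound 1 to compound 2 (0.21 log units; within the scatter), lies within the scatter and sits elsewhere on the shared core. Within the data shown here, with no precedent for the chloro-to-hydrogen change, the expected step in this assay is none beyond the scatter, with wide uncertainty in both directions.

Compound 3 is therefore estimated to give about 30000 nM, within a range of 12000 nM to 75000 nM. The expected step is a 1.0-fold lower number from compound 1 to compound 3 (0.01 log units; within the scatter).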

Compound 3, concentration for 50% growth inhibition: 37800 nM
For compound 3 the middle estimate is 1.3-fold (0.10 log units) below the measured one; the range from low to high includes it.
By their numbers in this assay, from the lowest: compounds 2, 1 and 3 (each within the scatter of the next).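

In this assay, for the compounds shown here, the first measured step at this aromatic carbon, a 1.2-fold higher number from compound 1 to compound 3 (0.09 log units; within the scatter), shows that hydrogen in place of chloro on the six-membered aromatic ring of carbon only does not separate the two compounds, at least with piperidin-1-yl on the chain. The earlier step, a 1.6-fold lower number from compound 1 to compound 2 (0.21 log units; within the scatter), concerned only the amine on the saturated chain carbon, so the series now has one single-place step at each of these two sites, and neither lies beyond the scatter. No supporting measurement bears on this result, and the numbers alone offer no explanation for it.

Chloro and hydrogen are the only substituents shown at this aromatic carbon, so it remains open whether a different group there, such as methoxy, nitro or a carboxylic acid, would give a number beyond the scatter of compound 1. From the compounds shown here alone, it also remains open whether hydrogen in place of chloro would read the same with diethylamino on the chain, or with another amine there such as morpholine.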